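Chloro Substitution and Plasma Protein Binding Across Two Cores

A few compounds are considered here, and "the series" means these few. Any claim that something is new, unique, unknown or untested is made for them only; others in the source may bear on it.

Compound 1 `Nc1nccc(COc2ccc3nc(N[C@@H]4CCCC[C@H]4O)sc3c2)c1Cl` and compound 2 `Nc1nccc(COc2cc(Cl)c3nc(N[C@@H]4CCCC[C@H]4O)sc3c2)c1Cl` share one core; compound 3 `COc1cc(OCc2ccnc(N)n2)cc2sc(N[C@H]3CCCC[C@@H]3O)nc12` and compound 4 `COc1cc(OCc2ccnc(N)n2)c(Cl)c2sc(N[C@H]3CCCC[C@@H]3O)nc12` share another. How the core of compound 3 differs from that of compound 1 is not broken down here.

In an ADME assay on a cell-free system (plasma, Homo sapiens) for protein binding, read by LC-MS, with a stated time of 5 h, tested at 5 uM, compound 1 gives > 99%, which is a limit of the assay. Compound 2 gives > 99% in this assay, again a limit. The change between them, (chloro in place of hydrogen on an aromatic carbon), therefore leaves the step that the two limits leave unreadable from compound 1 to compound 2 unreadable, a consequence of the limit of > 99% in this assay, at which 2 of the 3 values shown sit. For the measured compounds named here, compound 3 gives 77.6% in this assay, the only value here that is a number rather than a limit.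

Compound 4 carries the same kind of change relative to compound 3: chloro in place of hydrogen on an aromatic carbon. The surroundings of the place are not identical: in compound 2 the chloro is ortho to a fused ring, meta to a fused ring and meta to a large group, whereas in compound 4 it is ortho to a (2-aminopyrimidin-4-yl)methoxy group, ortho to a fused ring, meta to a fused ring and para to a methoxy group.

Because compound 3 gives 77.6%, a step can be read from it, unlike the earlier pair. The step expected is a 2.2-fold lower unbound fraction from compound 3 to compound 4 (0.35 log units; beyond the scatter), set beside the unreadable a step that the two limits leave unreadable from compound 1 to compound 2; it rests only on that unreadable earlier step and on the room left by compound 3.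

For compound 4 the estimate in this assay is 90%, expected to fall between 78% and 98%.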

Compound 4, plasma protein binding: 97.2%
The estimate for compound 4 lay 3.6-fold (0.55 log units) (unbound fraction) above the measured number, and the stated range covers the measured number.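

In this assay, chloro in place of hydrogen on an aromatic carbon gives an 8.0-fold lower unbound fraction from compound 3 to compound 4 (0.90 log units; beyond the scatter), so on the core of compound 3 the change goes with more of the compound bound to plasma protein, by a margin beyond the usual scatter. The same change on the core of compound 1 cannot be read, and the pair gives neither a size nor a direction to set beside the new step because compound 1 and compound 2 both sit at a limit of the assay: the limit of > 99% in this assay, at which 2 of the 4 values shown sit. The series therefore holds one readable instance of this change, which shows no transfer between the two cores, and the surroundings also differ, since the chloro in compound 4 is ortho to a (2-aminopyrimidin-4-yl)methoxy group and para to a methoxy group.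

The compounds shown leave open how a fluoro, a methyl or a nitrile at the place of the chloro in compound 4 would compare with it. Also open, on these data alone, is whether a carboxylic acid or an amine in place of the methoxy group would keep the chloro step on the core of compound 3 at a similar size.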